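The compounds below may be only part of what the source reports. "The series", "measured", "known", "first", "only" and "open" are said of these compounds alone.

Among the measured compounds shown here, compound 3 `CCCCc1ccc(-c2cc(N3CCC(CCNS(N)(=O)=O)CC3)ncn2)cc1` in a functional assay on HT-29 cells (Homo sapiens) for antiproliferative activity, read by sulforhodamine B assay, with a stated time of 48 h (on this read-out higher numbers stand for weaker inhibition of growth and lower numbers for stronger inhibition of growth), gives 13300 nM, the second highest of the three numbers measured so far. Its nearest neighbour is compound 1 `CC(C)(C)c1ccc(-c2cc(N3CCC(CNS(N)(=O)=O)CC3)ncn2)cc1`, which in this assay gives 8900 nM, a value within the scatter of that of compound 3. Compound 2 `Cc1ccc(-c2cc(N3CCC(CCNS(N)(=O)=O)CC3)ncn2)cc1` in this assay gives 52300 nM. Compound 4 `CC(C)(C)c1ccc(-c2cc(N3CCC(CCNS(N)(=O)=O)CC3)ncn2)cc1` has not yet been measured. It differs from compound 3 by tert-butyl in place of butyl on an aromatic carbon. For the measured compounds named here, only one measured step bears on this change: a 3.9-fold lower number from compound 2 to compound 3 (0.59 log units; beyond the scatter), in which a larger alkyl group on the aromatic ring went with a lower number. Going by the values given here, the change to compound 4 keeps the same atoms and alters only their arrangement, so no step of that size is expected; compound 1 carries the same tert-butyl group and its value sits close to that of compound 3. The number for compound 4 in this assay is therefore expected to lie near that of compound 3, if anything modestly lower, which is expressed as a 1.4-fold lower number from compound 3 to compound 4 (0.15 log units; within the scatter). Compound 4 is estimated at 9500 nM, with a range from 4000 nM to 25000 nM.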

Compound 4, concentration for 50% growth inhibition: 10300 nM
Compound 4: the middle estimate sits 1.1-fold (0.04 log units) below what was measured; the measured number falls inside the stated range.
By their numbers in this assay, from the lowest: compounds 1, 4 and 3 (each within the scatter of the next); then compound 2.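

In this assay, among the compounds shown here, tert-butyl in place of butyl on an aromatic carbon, para to a large group, gives a 1.3-fold lower number from compound 3 to compound 4 (0.11 log units; within the scatter), so at this position the two arrangements of the same four carbons cannot be told apart, something no earlier pair could show. Against methyl, tert-butyl gives a 5.1-fold lower number from compound 2 to compound 4 (0.71 log units; beyond the scatter), which stands alongside a 3.9-fold lower number from compound 2 to compound 3 (0.59 log units; beyond the scatter), so both four-carbon groups part from methyl beyond the scatter, and no listed compound goes against this. With tert-butyl held in place, (sulfamoylamino)methyl in place of sulfamoylamino on the saturated chain carbon gives a 1.2-fold higher number from compound 1 to compound 4 (0.06 log units; within the scatter), so this change in the side chain also stays within the scatter.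

The compounds shown leave open how a methoxy group, a trifluoromethyl group or a phenyl ring would fare on this aromatic carbon, and whether a carboxylic acid in place of the sulfamoylamino end would keep the number in this range. No measurement is at hand that would account for any of these numbers.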